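The source may report more compounds than this note shows. Statements on the series, on what has been measured and on what is new or still open speak of the compounds shown alone.

Measured so far in a functional assay on MGC-803 cells (Homo sapiens) for inhibition; on this read-out higher numbers stand for weaker inhibition and lower numbers for stronger inhibition: compound 1 `O=C(CC(CC(=O)NC1Cc2ccccc2C1)c1ccc(Cl)cc1)NCCN1CCCCC1` gives 89100 nM. Compound 2 `O=C(CC(CC(=O)NC1Cc2ccccc2C1)c1ccccc1)NCCN1CCCCC1` reaches only the limit of this assay, > 100000 nM. Compound 3 `CN(C(=O)CC(CC(=O)NCCN1CCCC1)c1ccccc1)C1Cc2ccccc2C1` likewise reaches only the limit of this assay, > 100000 nM.

Compound 4 `CN(C(=O)CC(CC(=O)NCCN1CCCC1)c1ccc(Cl)cc1)C1Cc2ccccc2C1` has not been measured. It differs from compound 3 by a single change, (chloro in place of hydrogen on an aromatic carbon). The same change, (chloro in place of hydrogen on an aromatic carbon), occurs once more among these compounds and there gave an at least 1.1-fold lower number from compound 2 to compound 1 (0.05 log units; that floor lies within the scatter). How the cores of compound 3 and compound 2 differ is not broken down here. The earlier step is hard to size because compound 2 sits at the limit of > 100000 nM in this assay, at which 2 of the 3 values shown sit. Among the measured compounds shown here, for compound 4 a step of about the same small size is expected, an at least 1.1-fold lower number from compound 3 to compound 4 (0.04 log units; that floor lies within the scatter), because the only precedent rests on (the limit of > 100000 nM in this assay, at which 2 of the 3 values shown sit). Compound 4 is therefore estimated at 90000 nM, with a real chance that the measurement again returns only a limit.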

Compound 4, half-maximal inhibitory concentration: 83800 nM
Beside the measured number, compound 4's estimate is 1.1-fold (0.03 log units) above it, within the range that was stated.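

In this assay, going from phenyl to 4-chlorophenyl gives an at least 1.1-fold lower number from compound 3 to compound 4 (0.07 log units; that floor lies within the scatter). Set beside the earlier case, the change can be read on two cores, but a comparison of its size stays out of reach: the same change on two cores in this assay, an at least 1.1-fold lower number (0.05 log units; that floor lies within the scatter) from compound 2 to compound 1 and an at least 1.1-fold lower number (0.07 log units; that floor lies within the scatter) from compound 3 to compound 4; the limit leaves it open whether they differ. Compound 1 and compound 4 each return a number while their unchlorinated partners, compound 2 and compound 3, return only a limit, so this shows the same direction at most and gives the true size of the change on neither core: the limit of > 100000 nM in this assay, at which 2 of the 4 values shown sit.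

Still open, from the compounds shown here alone, is whether bromo, methoxy or an amine in the same place would move the number further from that limit. Also open, going by these compounds, is whether a longer chain on either core would do so.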